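The source may report more compounds than this note shows. Statements on the series, on what has been measured and on what is new or still open speak of the compounds shown alone.

Compound 1, `Nc1cc(N)c2nc(-c3ccccc3)c(Oc3ccc(Cl)c(Cl)c3)nc2c1`, in a functional assay on SN12C cells (Homo sapiens) for inhibition, read by sulforhodamine B assay, with a stated time of 48 h (on this read-out lower numbers stand for higher toxicity in this test and higher numbers for lower toxicity in this test), gives < 100000 nM, which is a limit of the assay and not a number.
Compound 2, `CCOC(=O)[C@H](CCC(=O)O)NC(=O)c1ccc(CNc2nc3cc(N)cc(N)c3nc2-c2ccccc2)cc1`, in this assay gives < 100000 nM, likewise a limit.
Compound 3, `CCOC(=O)[C@H](CCC(=O)O)NC(=O)c1ccc(Sc2nc3cc(N)cc(N)c3nc2-c2ccccc2)cc1`, in this assay gives < 100000 nM, again a limit.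

Compound 1 therefore stands on a limit rather than on a measured number, and it is not alone in this: the two further values shown are limits as well, because the limit of < 100000 nM in this assay, at which 3 of the 3 values shown sit, describes where all three sit. Within the data shown here, none of the three compounds can be ranked against another on these data, and no step between any two measured compounds is available, since each differs from the others in more than one place.

Compound 4, `Nc1cc(N)c2nc(-c3ccccc3)c(NCc3ccc(F)cc3)nc2c1`, differs from compound 1 in one place: (4-fluorobenzyl)amino in place of 3,4-dichlorophenoxy on an aromatic carbon. Among the measured compounds shown here, no measured pair shows how such a change moves the read-out in this assay, so the size and direction of the step have to be guessed. The step from compound 1 to compound 4 in this assay is expected to be a step that the limit leaves unreadable from compound 1 to compound 4, with no clear direction beyond the usual scatter. Compound 4 is expected to give 40000 nM in this assay, between 8000 nM and 100000 nM, with a fair chance that only a limit is reported again.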

Compound 4, concentration lethal to 50% of the cells: 64600 nM
The estimate for compound 4 lay 1.6-fold (0.21 log units) below the measured number, within the range that was stated.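

No step can be read from compound 1 to compound 4, because compound 1 carries only a limit and not a number: the limit of < 100000 nM in this assay, at which 3 of the 4 values shown sit.

The compounds shown leave open whether (4-fluorobenzyl)amino in place of 3,4-dichlorophenoxy changes the result in this assay at all, and if it does, in which direction and by how much.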